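Sigma-1 binding: hydroxy versus acetoxy on the piperazine side chain

The source may hold more compounds than are shown below. What is called first, only, known or untested is meant among the compounds shown, and "the series" means these compounds.

For the measured compounds named here, compound 2 `CC(=O)OC(CCN1CCN(CCCN(c2ccc(F)cc2)c2ccc(F)cc2)CC1)c1ccccc1` gives 56.6 nM in an assay on membranes from brain for displacement of a labelled ligand from Sigma non-opioid intracellular receptor 1 (Cavia porcellus) (on this read-out higher numbers stand for weaker inhibition and lower numbers for stronger inhibition), and holds the highest of the two numbers measured so far; its nearest neighbour is compound 1 `O[C@H](Cc1ccccc1)CN1CCN(CCCN(c2ccc(F)cc2)c2ccc(F)cc2)CC1`, which gives 33.4 nM in this assay. Going by the values given here, the only step measured, a 1.7-fold higher number from compound 1 to compound 2 (0.23 log units; within the scatter), stays within the scatter.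

Compound 3 `O[C@@H](Cc1ccccc1)CN1CCN(CCCN(c2ccc(F)cc2)c2ccc(F)cc2)CC1` has not been measured. It differs from compound 2 by 1-hydroxy-2-phenylethyl in place of 2-acetoxy-2-phenylethyl on a saturated chain carbon bound to an amine nitrogen in a ring. Among the compounds with values here, this is the reverse of the measured step, except that the 1-hydroxy-2-phenylethyl group of compound 3 carries the opposite configuration at its defined stereocentre to the one in compound 1, and no measurement addresses that configuration.

The bearing step, from compound 1 to compound 2, was within the scatter, so the reverse exchange is expected to move the number by no more than the scatter, if at all, towards a slightly lower number; the unknown configuration widens the range. For compound 3 the estimate is 35 nM, with a range from 12 nM to 110 nM, meaning a step of a 1.6-fold lower number from compound 2 to compound 3 (0.21 log units; within the scatter) in this assay.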

Compound 3, inhibition constant: 28.1 nM
For compound 3 the middle estimate is 1.2-fold (0.10 log units) above the measured one, within the range that was stated.
By their numbers in this assay, from the lowest: compounds 3, 1 and 2 (each within the scatter of the next).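

In this assay the stereocentre of the 1-hydroxy-2-phenylethyl group now has a reading of its own, with a 1.2-fold lower number from compound 1 to compound 3 (0.08 log units; within the scatter), so the R and S forms as drawn cannot be told apart on this read-out. The comparison isolates that one feature: the fact that compounds 1 and 3 differ only in the configuration as drawn. The exchange of 2-acetoxy-2-phenylethyl for 1-hydroxy-2-phenylethyl on a saturated chain carbon bound to an amine nitrogen in a ring gives a 2.0-fold lower number from compound 2 to compound 3 (0.30 log units; within the scatter), which, like a 1.7-fold higher number from compound 1 to compound 2 (0.23 log units; within the scatter), is printed as within the scatter, so with either configuration of the hydroxy-bearing group the exchange shows no resolved effect at this position.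

The three compounds span only hydroxy and acetoxy forms of the side chain, all of them carrying a phenyl ring, so they do not show whether the oxygen function matters at all in this assay. From the compounds shown here alone, how an amine or a carboxylic acid in place of that oxygen function, or a longer chain between the piperazine nitrogen and the phenyl ring, would read remains open.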